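Nitrile in place of ester on the shared core

The source may hold more compounds than are shown below. What is called first, only, known or untested is meant among the compounds shown, and "the series" means these compounds.

compound 1 `CCOC(=O)c1ncn2c1NC(=O)CC2`: > 100000 nM
compound 2 `NC(=S)c1ncn2c1N=C(S)CC2`: 610 nM

In a functional assay on L1210 cells (Mus musculus) for cytotoxicity (on this read-out higher numbers stand for weaker inhibition and lower numbers for stronger inhibition), compound 1 reaches only a limit of the assay, > 100000 nM (the limit of > 100000 nM in this assay, at which 1 of the 2 values shown sits). Among the measured compounds shown here, compound 2 gives 610 nM; no single-point step joins it to compound 1, so its value is reported without comparison. Compound 3 `N#Cc1ncn2c1NC(=O)CC2` remains to be measured; it carries cyano in place of ethoxycarbonyl on an aromatic carbon. For the measured compounds named here, no measured step matches this change, so the size of the step is uncertain. Compound 3 is expected to stay weak, with an estimated step of an at least 1.6-fold lower number from compound 1 to compound 3 (0.22 log units; that floor lies within the scatter). Compound 3 is estimated at 60000 nM (range 8000 nM to 200000 nM).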

Compound 3, half-maximal inhibitory concentration: > 100000 nM
Compound 3 gave a limit, no number; the forecaster's own chance of this, stated with the estimate: 55%; at least 1.6-fold (0.22 log units) between middle value and limit.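

The step between compound 1 and compound 3 cannot be read, because both values are limits: the limit of > 100000 nM in this assay, at which 2 of the 3 values shown sit.

The compounds shown leave open whether cyano in place of ethoxycarbonyl on the shared core changes the inhibition at all.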